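A few compounds are considered here, and "the series" means these few. Any claim that something is new, unique, unknown or untested is made for them only; others in the source may bear on it.

Measured compounds in an assay on isolated protein for inhibition of DNA nucleotidylexotransferase (Homo sapiens), read by scintillation counting, with a stated time of 10 min; on this read-out lower numbers stand for stronger inhibition and higher numbers for weaker inhibition:
Compound 1 `CCOC(=O)C(=O)CC(=O)/C=C/c1cn(CCC(C)C)c2ccccc12`: > 40 uM, a limit of the assay.
Compound 2 `C=C(C)Cn1cc(/C=C/C(=O)CC(=O)C(=O)OCC)c2ccccc21`: > 40 uM, a limit of the assay.
Compound 3 `CCOC(=O)C(=O)CC(=O)/C=C/c1cn(-c2ccc(Cl)cc2)c2ccccc12`: > 40 uM, a limit of the assay.

Compound 2 therefore stands only at a limit, with no number of its own; all three measured values sit at the limit of > 40 uM in this assay, at which 3 of the 3 values shown sit. Compound 4 `CCOC(=O)C(=O)CC(=O)/C=C/c1cn(Cc2ccc(C#N)cc2)c2ccccc12` differs from compound 2 in one place: 4-cyanophenyl in place of 1-methylethenyl on a saturated chain carbon bound to an aromatic nitrogen. Of the measured steps, a step that the two limits leave unreadable from compound 2 to compound 3 puts a 4-chlorophenyl on an aromatic nitrogen, while a step that the two limits leave unreadable from compound 1 to compound 2 and a step that the two limits leave unreadable from compound 1 to compound 3 change that group in other ways; none of them can be read, as each end sits at the limit of > 40 uM in this assay, at which 3 of the 3 values shown sit. Within the data shown here, no step, then, sets a size or direction for the expected step that the limit leaves unreadable from compound 2 to compound 4, and the expectation is that compound 4 also gives a limit. The estimate for compound 4 in this assay is 50 uM, between 20 uM and 200 uM.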

Compound 4, concentration for 50% inhibition: > 40 uM
Compound 4: a limit, no number; the forecaster's own chance of this, stated with the estimate: 70%; the middle value is on the limit's open side.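

Compound 4 joins compound 1, compound 2 and compound 3 at a limit, so no step among these four compounds can be read: the limit of > 40 uM in this assay, at which 4 of the 4 values shown sit.

On these data alone, what stays open is whether any group on the aromatic nitrogen of the shared core gives a measurable number.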